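This account rests on a few compounds, and the source may have more. Where it says the series, first, only, none or still open, it means among the compounds named here.

Three compounds share a hydrazone linker that joins a dimethoxy-substituted benzene ring to a thiazole bearing an aryl group. Compound 1 `COc1cc(/C=N/Nc2nc(-c3cc(C(F)(F)F)cc(C(F)(F)F)c3)cs2)cc(Br)c1OC` carries two trifluoromethyl groups on that aryl ring, while compound 3 `COc1cc(/C=N/Nc2nc(-c3ccccc3)cs2)cc(Br)c1OC` and compound 2 `COc1cc(/C=N/Nc2nc(-c3ccccc3)cs2)c(Br)c(Br)c1OC` carry a plain phenyl. How the core of compound 1 differs from the core of compound 3 is not broken down here.

In a functional assay on A549 cells (Homo sapiens) for inhibition, read by MTT assay, with a stated time of 48 h (on this read-out lower numbers stand for stronger inhibition and higher numbers for weaker inhibition), compound 1 gives 94200 nM, the highest of the three values. Compound 3 gives 40000 nM and compound 2 gives 15300 nM. The change from compound 3 to compound 2 is bromo in place of hydrogen on an aromatic carbon and it produced a 2.6-fold lower number from compound 3 to compound 2 (0.42 log units; beyond the scatter).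

Compound 4 `COc1cc(/C=N/Nc2nc(-c3cc(C(F)(F)F)cc(C(F)(F)F)c3)cs2)c(Br)c(Br)c1OC` has not yet been measured. Among the measured compounds shown here, it arises from compound 1 by bromo in place of hydrogen on an aromatic carbon, the same change, placed in the same surroundings, as the one that led from compound 3 to compound 2. Because that earlier change gave a 2.6-fold lower number from compound 3 to compound 2 (0.42 log units; beyond the scatter), a step of a similar size is expected here, namely a 2.5-fold lower number from compound 1 to compound 4 (0.39 log units; beyond the scatter). On that basis compound 4 is estimated at 38000 nM, with a likely range from 15000 nM to 90000 nM.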

Compound 4, half-maximal inhibitory concentration: > 100000 nM
Compound 4: no number, only a limit; the forecaster's own chance of this, stated with the estimate: 10%; middle value at least 2.6-fold (0.42 log units) from the limit.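

In this assay compound 4 gives > 100000 nM, which is a limit of the assay and not a number. The step is an at least 1.0-fold higher number from compound 1 to compound 4 (0.02 log units; that floor lies within the scatter), so the drop seen with the plain phenyl compounds did not carry over to the compounds with two trifluoromethyl groups, and the same change gave different results on the two cores: the same change on two cores in this assay, a 2.6-fold lower number (0.42 log units; beyond the scatter) from compound 3 to compound 2 and an at least 1.0-fold higher number (0.02 log units; that floor lies within the scatter) from compound 1 to compound 4, at least 2.7-fold (0.44 log units) apart, beyond the scatter of two such steps This does not give a true value for compound 4 or show which difference between the cores is responsible, and a single pair on each core is too little to support a general rule for the series.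

The compounds shown leave open how the same bromo change would behave with a single trifluoromethyl group on the aryl ring, or with an amine or a carboxylic acid there. From the compounds shown here alone, it also remains open whether a chloro or a hydroxy group entering at the same place would follow the bromo results on either core.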